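The compounds below may be only part of what the source reports. "The series", "measured", "known", "first", "only" and "open" are said of these compounds alone.

Two measured members of the series are available, and they differ from each other in two places at once. Compound 1 `O=C(Nc1cccc(-n2cc(-c3ccncc3)c(-c3ccc(Cl)c(O)c3)n2)c1)Nc1cccc(C(F)(F)F)c1` carries a hydroxy group; in a functional assay on MDA-MB-468 cells (Homo sapiens) for inhibition, read by sulforhodamine B assay, with a stated time of 48 h (a higher number here means a weaker inhibitor of growth, a lower number a stronger inhibitor of growth), compound 1 gives 980 nM. Compound 2 `COc1cc(-c2nn(-c3cccc(NC(=O)Nc4cc(C(F)(F)F)cc(C(F)(F)F)c4)c3)cc2-c2ccncc2)ccc1Cl` carries a methoxy group instead and differs from compound 1 elsewhere as well; in this assay compound 2 gives 307 nM. Compound 2 thus stands at the lower of the two numbers, separated from compound 1 by more than the usual scatter, but with two changes between them no single change can be credited with the gap. Compound 3 `O=C(Nc1cccc(-n2cc(-c3ccncc3)c(-c3ccc(Cl)c(O)c3)n2)c1)Nc1cc(C(F)(F)F)cc(C(F)(F)F)c1` keeps everything of compound 2 except one exchange: hydrogen in place of methyl on an oxygen on an aromatic ring. Among the compounds with values here, no measured pair isolates this exchange, so its direction is open; the only hint is that the hydroxy-bearing compound 1 sits at the higher number, which argues weakly for a modest rise. A step of a 1.5-fold higher number from compound 2 to compound 3 (0.17 log units; within the scatter) is expected, of a size near the scatter. For compound 3 in this assay a value of 450 nM is estimated, with a range from 150 nM to 1300 nM.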

Compound 3, concentration for 50% growth inhibition: 265 nM
The estimate for compound 3 lay 1.7-fold (0.23 log units) above the measured number; the range from low to high includes it.
By their numbers in this assay, from the lowest: compounds 3 and 2 (each within the scatter of the next); then compound 1.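

In this assay, exchanging methoxy for hydroxy on the 4-chloro-3-methoxyphenyl group gives a 1.2-fold lower number from compound 2 to compound 3 (0.06 log units; within the scatter), so this position tolerates the change with the second trifluoromethyl group present, and neither group can be ranked over the other here. Within the data shown here, the other difference between the earlier compounds can now be read alone: with hydroxy held constant, trifluoromethyl in place of hydrogen on an aromatic carbon gives a 3.7-fold lower number from compound 1 to compound 3 (0.57 log units; beyond the scatter), a modest step and the only one in this small set that clears the scatter. No measured evidence bears on why the first exchange leaves the number within the scatter or why the second lowers it.

Among these compounds, the methoxy-to-hydroxy result rests on a single pair and on one background, so it remains open whether the same exchange would also stay within the scatter with only one trifluoromethyl group on the urea-bearing ring. Also open, going by these compounds, is how far this position's tolerance extends, for instance to an amine in place of hydroxy or to a longer chain such as ethoxy in place of methoxy.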